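Ring hydroxy removal in a nucleoside series: expected step

The source may report more compounds than this note shows. Statements on the series, on what has been measured and on what is new or still open speak of the compounds shown alone.

Of the compounds shown here, three have been measured in an assay on CHO cells for displacement of a labelled ligand from adenosine receptor A3 (Homo sapiens), tested at 10 uM; on this read-out higher numbers stand for more inhibition at the one concentration tested (going by the name of the read-out) and lower numbers for less inhibition. Compound 1 `Nc1ncnc2c1ncn2[C@@H]1OC[C@@](O)(CO)[C@H]1O` gives 10% in this assay. Compound 2 `Nc1ncnc2c1ncn2[C@@H]1OC[C@H](CO)[C@H]1O` gives 32%. Compound 3 `Nc1ncnc2c1ncn2[C@@H]1OC[C@](O)(CO)[C@H]1O` gives 35% and stands highest of the three, though its gap to compound 2 lies within the scatter, so no order between those two is claimed.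

Two measured steps are available. From compound 1 to compound 2 the change is hydrogen in place of hydroxy on a saturated ring carbon, and this assay moves a number 22 percentage points higher from compound 1 to compound 2 (beyond the scatter). From compound 1 to compound 3 the change is the two compounds have the same atoms and bonds and differ only in configuration as drawn: 1 of 3 stereo elements differ; a stereocentre at a saturated ring carbon is drawn S in compound 1 and R in compound 3, and this assay moves a number 25 percentage points higher from compound 1 to compound 3 (beyond the scatter); the cause of that step can only be put down to the fact that compounds 1 and 3 differ only in the configuration as drawn.

Compound 4 `Nc1ncnc2c1ncn2[C@@H]1OC[C@@H](CO)[C@H]1O` has not yet been measured. From compound 3 to compound 4 the change is hydrogen in place of hydroxy on a saturated ring carbon, the same change as from compound 1 to compound 2 at the same place, made here on the core of compound 3 rather than the core of compound 1. Going by the values given here, the earlier step gives the only measured guide. Because that step on compound 1 is a number 22 percentage points higher from compound 1 to compound 2 (beyond the scatter), a step of similar direction is expected from compound 3 to compound 4, but with a smaller size, since the starting point of compound 3 already stands higher; the expected step is a number 10 percentage points higher from compound 3 to compound 4 (within the scatter). Compound 4 is thus estimated at 45% in this assay, with a range from 25% to 65%.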

Compound 4, a percentage reported as inhibition, at one concentration (the size of the read-out at that concentration, not a potency): 7%
Compound 4: the middle estimate sits 38 percentage points above what was measured; measured number below the stated range.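

In this assay, hydrogen in place of hydroxy on this saturated ring carbon gives a number 28 percentage points lower from compound 3 to compound 4 (beyond the scatter), so the change does not carry from the core of compound 1 to the core of compound 3 with either its direction or its size, and the earlier step cannot serve as a guide across these two cores: the same change on two cores in this assay, a number 22 percentage points higher (beyond the scatter) from compound 1 to compound 2 and a number 28 percentage points lower (beyond the scatter) from compound 3 to compound 4, 50 percentage points apart, beyond the scatter of two such steps. With the hydroxy gone, inverting a single drawn stereocentre gives a number 25 percentage points lower from compound 2 to compound 4 (beyond the scatter), so in this pair the configuration alone goes with a step beyond the scatter, and the outcome of the hydroxy removal depends on which configuration the core carries: the fact that compounds 2 and 4 differ only in the configuration as drawn. This shows a dependence on the core for one change across four compounds, but it does not show why the two steps part, nor does it set a rule for any other core in the series.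

The compounds shown leave open whether an amine or a fluorine on the same ring carbon would split between the two configurations as hydrogen does. They also leave open whether a longer chain in place of the hydroxymethyl group would keep the same dependence on configuration.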